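Swapping an oxane ring for a fluorinated chain

A few compounds are considered here, and "the series" means these few. Any claim that something is new, unique, unknown or untested is made for them only; others in the source may bear on it.

compound 1 `Cc1ccc(C(=O)Nc2cn3ncnc3c(CN3CCN(C(=O)C4CCOCC4)[C@@H](C)C3)c2C)cn1`: < 10 mL.min-1.g-1
compound 2 `Cc1ccc(C(=O)Nc2cc(F)cc(CN3CCN(C(=O)C4CCCC4)[C@@H](C)C3)c2C)cn1`: 88 mL.min-1.g-1
compound 3 `Cc1ccc(C(=O)Nc2cn3ncnc3c(O[C@@H]3CCN(C(=O)CC(C(F)(F)F)C(F)(F)F)[C@@H](C)C3)c2C)cn1`: 28 mL.min-1.g-1

Of the compounds shown here, three from this series have been tested in an ADME assay on microsomes from liver (Homo sapiens) for metabolic stability; on this read-out higher numbers stand for fast clearance and lower numbers for slow clearance. Compound 1 gives < 10 mL.min-1.g-1, which is a limit of this assay and not a number; compound 1 sits at the limit of < 10 mL.min-1.g-1 in this assay, at which 1 of the 3 values shown sits. Compound 2 gives 88 mL.min-1.g-1, and compound 3 gives 28 mL.min-1.g-1. Compound 4 `Cc1ccc(C(=O)Nc2cn3ncnc3c(CN3CCN(C(=O)CC(C(F)(F)F)C(F)(F)F)[C@@H](C)C3)c2C)cn1` has not yet been measured. It differs from compound 1 in one place: 3,3,3-trifluoro-2-(trifluoromethyl)propyl in place of oxan-4-yl on a carbonyl carbon. Among the compounds with values here, no step between two measured compounds is available, so the size of this change must be guessed. Compound 3 carries the same fluorinated chain on a related core and gives 28 mL.min-1.g-1, which guides the expectation. For compound 4 a rise beyond the scatter toward faster clearance is expected, an at least 2.5-fold higher number from compound 1 to compound 4 (0.39 log units; beyond the scatter). Compound 4 is estimated at 25 mL.min-1.g-1, within 8 mL.min-1.g-1 to 60 mL.min-1.g-1.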

Compound 4, intrinsic clearance in microsomes: < 10 mL.min-1.g-1
Compound 4 gave a limit, no number; the forecaster's own chance of this, stated with the estimate: 25%; middle value at least 2.5-fold (0.39 log units) from the limit.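

Compound 1 and compound 4 both give a limit rather than a number in this assay, so no step between them can be read: the limit of < 10 mL.min-1.g-1 in this assay, at which 2 of the 4 values shown sit.

From the compounds shown here alone, what the swap from oxan-4-yl to 3,3,3-trifluoro-2-(trifluoromethyl)propyl does to clearance on this core stays open.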